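Tert-butyl for Methyl on a Selenium-Bearing Bis-Benzamide Core

The source may hold more compounds than are shown below. What is called first, only, known or untested is meant among the compounds shown, and "the series" means these compounds.

This series turns on a single read-out, a functional assay on PC-3 cells (Homo sapiens) for cytotoxicity, read by MTT assay; a higher number here means a weaker inhibitor, a lower number a stronger inhibitor. Compound 1 `C[Se]/C(=N\C(=O)c1ccccc1)NC(=O)c1ccccc1` gives 2500 nM. Compound 2 `CS/C(=N\C(=O)c1ccc(C)cc1)NC(=O)c1ccc(C)cc1` is reported only as a limit, > 10000 nM, and not as a number. Compound 3 `C[Se]/C(=N\C(=O)c1ccc(C)cc1)NC(=O)c1ccc(C)cc1` gives 1850 nM, the lowest of the two numbers recorded, with compound 1 close enough that the two sit within the usual scatter of each other. Among the compounds with values here, the one measured step, an at least 5.4-fold lower number from compound 2 to compound 3 (0.73 log units; beyond the scatter), rests on the limit of > 10000 nM in this assay, at which 1 of the 3 values shown sits, and concerns the exchange at the carbon doubly bonded to nitrogen, not the aromatic rings.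

Compound 4 `C[Se]/C(=N\C(=O)c1ccc(C(C)(C)C)cc1)NC(=O)c1ccc(C)cc1` differs from compound 3 by tert-butyl in place of methyl on an aromatic carbon. Within the data shown here, no measured step touches that position, so nothing here speaks to the direction or size of the change. The step is therefore expected to fall within the scatter, a 1.2-fold lower number from compound 3 to compound 4 (0.06 log units; within the scatter). Compound 4 is estimated at 1600 nM, with a range from 500 nM to 5000 nM.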

Compound 4, half-maximal inhibitory concentration: > 10000 nM
Compound 4: a limit, no number (the forecaster's own chance of this, stated with the estimate: 5%); middle value at least 6.2-fold (0.79 log units) from the limit.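

In this assay, within the data shown here, the exchange at this aromatic carbon, a position no earlier step touched, gives an at least 5.4-fold higher number from compound 3 to compound 4 (0.73 log units; beyond the scatter), so this position does not accept every group. Compound 4 keeps the selenium-bearing group that separates compound 3 from compound 2, which shows that this group alone does not keep the value clear of the limit. The value of compound 4 is a limit and not a number, so the true size of the step stays unknown on its upper side: the limit of > 10000 nM in this assay, at which 2 of the 4 values shown sit.

From the compounds shown here alone, whether an ethyl or isopropyl group at this position would give a number or a limit stays open, as does the outcome with an amine or a carboxylic acid there. Also open, going by these compounds, is what tert-butyl would do on the second aromatic ring, which still carries methyl in compound 4.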